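Trifluoromethyl in place of fluoro: notes on compound 3

The source may hold more compounds than are shown below. What is called first, only, known or untested is meant among the compounds shown, and "the series" means these compounds.

In a functional assay on A549 cells (Homo sapiens) for inhibition, read by sulforhodamine B assay (a lower number here means a stronger inhibitor of growth, a higher number a weaker inhibitor of growth), compound 1 (`Oc1cccc2[nH]c(-c3ccc(-c4ccc(-c5ccc(C(F)(F)F)cc5)cc4)cc3)nc12`) gives 3610 nM and compound 2 (`Cc1ccc2[nH]c(-c3ccc(-c4ccc(-c5ccc(F)cc5)cc4)cc3)nc2c1`) gives 6030 nM. These two values lie within the usual scatter of each other, so the numbers available do not separate compound 2 from compound 1.

Compound 3 (`Cc1ccc2[nH]c(-c3ccc(-c4ccc(-c5ccc(C(F)(F)F)cc5)cc4)cc3)nc2c1`) keeps the rest of compound 2 but carries trifluoromethyl in place of fluoro on an aromatic carbon, para to a large group (trifluoromethyl in place of fluoro on an aromatic carbon). The same difference can be read as 4-fluorophenyl to 4-(trifluoromethyl)phenyl. Among the measured compounds shown here, no measured pair shows this change alone, so the data give no direct size for it.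

Compound 1 also carries the 4-(trifluoromethyl)phenyl group and gives 3610 nM, which offers only indirect support for a value in the same range. No shift beyond the scatter is therefore expected in this assay, and the expected 1.3-fold lower number from compound 2 to compound 3 (0.13 log units; within the scatter) is small and slightly towards stronger growth inhibition. Compound 3 is estimated at 4500 nM, with an expected range of 2000 nM to 10000 nM.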

Compound 3, concentration for 50% growth inhibition: 3520 nM
Compound 3: the middle estimate sits 1.3-fold (0.11 log units) above what was measured; low and high end bracket the measured number.
By their numbers in this assay, from the lowest: compounds 3, 1 and 2 (each within the scatter of the next).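

In this assay, among the compounds shown here, the step of a 1.7-fold lower number from compound 2 to compound 3 (0.23 log units; within the scatter) gives the first direct reading of trifluoromethyl in place of fluoro on an aromatic carbon, para to a large group, and this exchange does not move the number beyond the scatter. For the compounds shown here, with the 4-(trifluoromethyl)phenyl group held constant, the step of a 1.0-fold lower number from compound 1 to compound 3 (0.01 log units; within the scatter) gives the first direct reading of 5-methyl-1H-benzimidazol-2-yl in place of 4-hydroxy-1H-benzimidazol-2-yl, and this exchange also stays within the scatter, so neither single-place change separates the compounds in this small set. No available evidence bears on either step.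

Whether an amine, a carboxylic acid or a longer chain on this aromatic carbon would give a step beyond the scatter remains open, as the compounds shown cover only fluoro and trifluoromethyl here. Also open, as far as these compounds go, is whether the exchange between 5-methyl-1H-benzimidazol-2-yl and 4-hydroxy-1H-benzimidazol-2-yl would stay within the scatter with the 4-fluorophenyl group in place of 4-(trifluoromethyl)phenyl.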